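The compounds below may be only part of what the source reports. "The series", "measured", "known", "first", "only" and "open" are said of these compounds alone.

Measured so far: compound 1 `Nc1ccccc1-c1cnc(C(=O)CCCCCCc2ccccc2)o1`, 750 nM; compound 2 `O=C(CCCCCCc1ccccc1)c1ncc(-c2ccc(F)cc2)o1`, 62 nM; compound 3 `O=C(CCCCCCc1ccccc1)c1ncc(-c2ccc(C(=O)C(F)(F)F)cc2)o1`, 65 nM; all in an assay (Rattus norvegicus) for inhibition of Fatty-acid amide hydrolase 1 (Homo sapiens); a lower number here means a stronger inhibitor, a higher number a weaker inhibitor.

Compound 2 gives the lowest number of the three; compound 3 sits within the scatter of it, and compound 1 lies well beyond it. The unmeasured compound 4 `O=C(CCCCCCc1ccccc1)c1ncc(-c2ncccc2C(=O)O)o1` differs from compound 2 in one place: 3-carboxypyridin-2-yl in place of 4-fluorophenyl on an aromatic carbon.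

Within the data shown here, two steps bear on this position. The step of a 1.0-fold higher number from compound 2 to compound 3 (0.02 log units; within the scatter) shows that a large substituent on the pendant ring is tolerated, while the step of a 12-fold lower number from compound 1 to compound 2 (1.08 log units; beyond the scatter) shows that the nature of the pendant aromatic group can move the number substantially. The change to compound 4 is larger than either, so a weaker number is expected, on the order of a 6.5-fold higher number from compound 2 to compound 4 (0.81 log units; beyond the scatter). Compound 4 is expected at 400 nM, within a range of 100 nM to 2000 nM.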

Compound 4, inhibition constant: > 50 nM
Compound 4: a limit, no number; the forecaster's own chance of this, stated with the estimate: 5%; the middle value lies beyond the limit too.
By their numbers in this assay, from the lowest: compounds 2 and 3 (each within the scatter of the next); then compound 1.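

In this assay compound 4 gives > 50 nM, a limit and not a number. The steps to compound 4 from compound 1 and compound 2 cannot be read. Where compound 4 stands relative to compounds 1, 2 and 3 stays open.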